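The source may hold more compounds than are shown below. What is called first, only, known or untested is meant among the compounds shown, and "the series" means these compounds.

Compound 1 `CCCCCCCCCCCC(=O)NC(CCCCN)C(=O)NCCCCCCCCCCCC(=O)NC(CCCCN)C(=O)O` was examined in an ADME assay on MDCK cells (Canis lupus familiaris) for cytotoxicity, read by resazurin assay, with a stated time of 3.5 h; on this read-out higher numbers stand for weaker inhibition and lower numbers for stronger inhibition. In this assay compound 1 gives > 100000 nM, which is a limit of the assay rather than a number. The only other result in the set belongs to compound 2 `NCCCCCCCCCCCC(=O)NC(CCCCN)C(=O)NCCCCCCCCCCCC(=O)NC(CCCCN)C(=O)NCCCCCCCCCCCC(=O)NC(CCCCN)C(=O)O`, a longer chain built from the same kind of units. In this assay compound 2 gives 91000 nM. On the numbers shown, compound 1 stands at the limit of > 100000 nM in this assay, at which 1 of the 2 values shown sits. Compound 3 `NCCCCCCCCCCCC(=O)NC(CCCCN)C(=O)NCCCCCCCCCCCC(=O)NC(CCCCN)C(=O)O` has not yet been measured in this assay. It differs from compound 1 by amino in place of hydrogen on a saturated chain carbon, ten or more bonds along the chain from a carbonyl carbon. Among the compounds with values here, no measured pair isolates this change, so the step is expected to be a number no higher from compound 1 to compound 3 (the limit leaves the size open), with no movement expected beyond the scatter. Compound 3 is expected to give about 100000 nM, within a range from 50000 nM to 300000 nM.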

Compound 3, half-maximal inhibitory concentration: > 150000 nM
Compound 3: only a limit was reported; the forecaster's own chance of this, stated with the estimate: 55%; at least 1.5-fold (0.17 log units) between middle value and limit.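

In this assay, within the data shown here, compound 1 and compound 3 are each reported only as a limit and not as a number, so no step between them can be read. The compounds shown leave open whether amino in place of hydrogen on a saturated chain carbon, ten or more bonds along the chain from a carbonyl carbon, changes this read-out at all.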